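Swapping the aryl group on the thiazole core of compound 2

This account rests on a few compounds, and the source may have more. Where it says the series, first, only, none or still open, it means among the compounds named here.

For the measured compounds named here, compound 2, `N#Cc1cc(-c2nc(C(c3ccc(F)cc3)c3ccc(F)cc3)sc2CC(=O)O)ccc1F`, stands as the weaker of the two compounds measured so far in an in vitro functional assay on HEK285-7 cells for antagonist activity at prostaglandin D2 receptor 2 (Homo sapiens), read by BRET and beta-arrestin recruitment (a lower number here means a stronger inhibitor, a higher number a weaker inhibitor), where compound 2 gives 520 nM. Going by the values given here, its nearest neighbour, compound 1, `O=C(O)Cc1sc(C(c2ccc(F)cc2)c2ccc(F)cc2)nc1-c1cccc(F)c1`, gives 18 nM in this assay; the single one-place step measured, a 29-fold higher number from compound 1 to compound 2 (1.46 log units; beyond the scatter), is the replacement of 3-fluorophenyl by 3-cyano-4-fluorophenyl on the aromatic carbon of the shared core.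

Compound 3, `NS(=O)(=O)c1cccc(-c2nc(C(c3ccc(F)cc3)c3ccc(F)cc3)sc2CC(=O)O)c1`, differs from compound 2 in one place: 3-sulfamoylphenyl in place of 3-cyano-4-fluorophenyl on an aromatic carbon. Among the compounds with values here, no measured step involves 3-sulfamoylphenyl, so the only guidance is indirect. The step from compound 1 to compound 2 shows that this position tolerates 3-fluorophenyl far better than 3-cyano-4-fluorophenyl, and compound 3 returns to a single substituent on that ring, though one of a different kind. On that basis compound 3 is expected to give a lower number than compound 2, estimated as a 3.5-fold lower number from compound 2 to compound 3 (0.54 log units; beyond the scatter), with wide uncertainty because a single step, a 29-fold higher number from compound 1 to compound 2 (1.46 log units; beyond the scatter), is all there is to draw on. The estimate for compound 3 in this assay is 150 nM, within a range from 25 nM to 1000 nM.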

Compound 3, half-maximal inhibitory concentration: 710 nM
Estimate against measurement, compound 3: 4.7-fold (0.68 log units) below, and the stated range covers the measured number.
By their numbers in this assay, from the lowest: compound 1; then compounds 2 and 3 (each within the scatter of the next).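

In this assay, the change from 3-cyano-4-fluorophenyl to 3-sulfamoylphenyl is a 1.4-fold higher number from compound 2 to compound 3 (0.14 log units; within the scatter), so these two quite different groups, one with a hydrogen-bond donor and one without, cannot be told apart here. Carrying a single substituent on the ring is also not enough to keep the number of compound 1: sulfamoyl in place of fluoro on that ring is a 39-fold higher number from compound 1 to compound 3 (1.60 log units; beyond the scatter), a large step in the same direction as a 29-fold higher number from compound 1 to compound 2 (1.46 log units; beyond the scatter), so that among these three compounds only the 3-fluorophenyl compound has the low number. Nothing available explains why either replacement costs so much at this place on the shared core.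

The compounds shown leave open whether the low number of compound 1 is particular to fluoro or would also hold for a small group such as chloro, methyl or methoxy on the same ring, or for an unsubstituted phenyl. They also leave open what the nitrile does on its own, without the second fluorine of compound 2, and whether a smaller relative of sulfamoyl, such as a methylsulfonyl group, would behave like compound 3.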